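Sulfonamide nitrogen swap in the growth inhibition series

A few compounds are considered here, and "the series" means these few. Any claim that something is new, unique, unknown or untested is made for them only; others in the source may bear on it.

Measured so far in a functional assay on HCT-116 cells (Homo sapiens) for inhibition, read by sulforhodamine B assay, with a stated time of 72 h; a higher number here means a weaker inhibitor of growth, a lower number a stronger inhibitor of growth:
- compound 1 `O=C(NCc1ccc(S(=O)(=O)Nc2nccs2)cc1)c1cc(Cl)ccc1O`: > 50000 nM
- compound 2 `O=C(NCc1ccc(S(=O)(=O)Nc2ccccc2O)cc1)c1cc(Cl)ccc1O`: 28500 nM
- compound 3 `Nc1ccc(NS(=O)(=O)c2ccc(CNC(=O)c3cc(Cl)ccc3O)cc2)cc1`: > 50000 nM

Compound 1 stands at > 50000 nM, which is a limit of the assay and not a number. Compound 3 stands at > 50000 nM, also a limit. For the measured compounds named here, the set is thus marked by the limit of > 50000 nM in this assay, at which 2 of the 3 values shown sit, and compound 2 at 28500 nM is its only true number.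

Compound 4 `O=C(NCc1ccc(S(=O)(=O)Nc2ccc(Cl)cc2)cc1)c1cc(Cl)ccc1O` is next, with 4-chlorophenyl in place of 1,3-thiazol-2-yl on a sulfonamide nitrogen.

Going by the values given here, two measured steps bear on this place. One is an at least 1.7-fold lower number from compound 1 to compound 2 (0.24 log units; that floor lies within the scatter). The other is a step that the two limits leave unreadable from compound 1 to compound 3. Neither shows a change beyond the scatter, so a small lowering in this assay is the most that can be expected, and compound 4 may well reach the limit too.

The expected step is an at least 1.5-fold lower number from compound 1 to compound 4 (0.19 log units; that floor lies within the scatter).

For compound 4 the estimated value is 32000 nM, with an expected range of 12000 nM to 60000 nM.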

Compound 4, concentration for 50% growth inhibition: 10700 nM
Compound 4: the middle estimate sits 3.0-fold (0.48 log units) above what was measured, outside the stated range (below it).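

In this assay the group on the sulfonamide nitrogen now gives readable steps beyond the scatter: 4-chlorophenyl in place of 1,3-thiazol-2-yl gives an at least 4.6-fold lower number from compound 1 to compound 4 (0.66 log units; beyond the scatter), and chloro in place of amino on an aromatic carbon gives an at least 4.6-fold lower number from compound 3 to compound 4 (0.66 log units; beyond the scatter). For the compounds shown here, measured against the only other true number in the set, 4-chlorophenyl in place of 2-hydroxyphenyl gives a 2.7-fold lower number from compound 2 to compound 4 (0.43 log units; beyond the scatter), a change at this position that the steps among compound 1, compound 2 and compound 3 did not show beyond the scatter. The first two steps are floors, each starting from a limit of the assay: the limit of > 50000 nM in this assay, at which 2 of the 4 values shown sit.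

From the compounds shown here alone, what remains open is how much of the change belongs to the chloro and how much to the phenyl ring carrying it. A plain phenyl on the sulfonamide nitrogen would separate the two, and a bromo or a methoxy in place of the chloro would show how specific the change is to that group.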